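The source may hold more compounds than are shown below. What is called first, only, known or untested is meant among the compounds shown, and "the series" means these compounds.

Of the compounds shown here, two carry a measured number so far. Compound 1 `COc1ccc(OC)c(/C=C/c2nnc(Nc3ccc(Cl)cc3)o2)c1` and compound 2 `COc1ccc(OC)c(/C=C/C(=O)N/N=C/c2ccc(Cl)cc2)c1` share the same left-hand piece and differ in how it is joined to the chlorine-bearing ring. In a functional assay on COLO 205 cells (Homo sapiens) for antiproliferative activity, read by sulforhodamine B assay, with a stated time of 48 h (on this read-out lower numbers stand for stronger inhibition of growth and higher numbers for weaker inhibition of growth), compound 1 gives 16600 nM, while compound 2 gives 153 nM; compound 2 thus holds the lower of the two numbers, and its gap to compound 1 lies well beyond the scatter. Compound 3 `COc1ccc(OC)c(/C=C/C(=O)N/N=C/c2ccccc2)c1` has not yet been measured. It differs from compound 2 by hydrogen in place of chloro on an aromatic carbon. Among the compounds with values here, no step between two measured compounds in this assay isolates such a change, so its size cannot be read off and can only be expected. The account expects a modest weakening from compound 2 to compound 3, a 2.3-fold higher number from compound 2 to compound 3 (0.36 log units; beyond the scatter), close to the edge of the scatter. Compound 3 is therefore estimated at 350 nM, with a range from 100 nM to 1500 nM.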

Compound 3, concentration for 50% growth inhibition: 4800 nM
Beside the measured number, compound 3's estimate is 14-fold (1.14 log units) below it, outside the stated range (above it).
By their numbers in this assay, from the lowest: compound 2; then compound 3; then compound 1.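

In this assay the exchange of 4-chlorophenyl to phenyl, with nothing else altered, gives a 31-fold higher number from compound 2 to compound 3 (1.50 log units; beyond the scatter) and so marks this place on the ring, para to a large group, as one where a single atom changes the number strongly. Compounds 1 and 2 could not show this, as both carry the chloro and differ instead in how the left-hand piece is joined to that ring. Nothing at hand accounts for the size of this step.

With only chloro and hydrogen shown at this place, it remains open whether a fluoro, a methoxy or an amine there would hold the number of compound 2 or lose it as compound 3 does. Also open, going by these compounds, is whether the same exchange would weigh as heavily on compound 1, whose joining piece is different.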